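Pyridine-linked trishydroxyphenyl series: cytotoxicity on HCT-15 cells

The source may report more compounds than this note shows. Statements on the series, on what has been measured and on what is new or still open speak of the compounds shown alone.

Three members of the series are measured. Compound 1 `Oc1ccc(-c2cc(-c3cccc(O)c3)cc(-c3cccc(O)c3)n2)cc1` gives 3090 nM in a functional assay on HCT-15 cells (Homo sapiens) for cytotoxicity, read by CCK-8 assay, with a stated time of 4 days; a higher number here means a weaker inhibitor, a lower number a stronger inhibitor. Compound 2 `Oc1ccc(-c2cc(-c3ccc(O)cc3)nc(-c3cccc(O)c3)c2)cc1` gives 3520 nM in this assay, and compound 3 `Oc1ccc(-c2cc(-c3cccc(O)c3)nc(-c3ccccc3O)c2)cc1` gives 5830 nM in this assay. The change from compound 1 to compound 2 is 4-hydroxyphenyl in place of 3-hydroxyphenyl on an aromatic carbon, and its step is a 1.1-fold higher number from compound 1 to compound 2 (0.06 log units; within the scatter). The change from compound 2 to compound 3 gives a 1.7-fold higher number from compound 2 to compound 3 (0.22 log units; within the scatter). The difference between the cores of compound 1 and compound 3 is not broken down here. All three numbers lie within the usual scatter of one another, so no order among them is claimed.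

Compound 4 `Oc1ccc(-c2cc(-c3ccc(O)cc3)nc(-c3ccccc3O)c2)cc1` is not yet measured. It differs from compound 3 by 4-hydroxyphenyl in place of 3-hydroxyphenyl on an aromatic carbon. This is the same kind of change as that from compound 1 to compound 2, but not the same: in compound 1 the group that leaves stands opposite the ring nitrogen and meta to a 3-hydroxyphenyl group, whereas in compound 3 it stands next to the ring nitrogen and meta to a 2-hydroxyphenyl group. The earlier step, a 1.1-fold higher number from compound 1 to compound 2 (0.06 log units; within the scatter), lay within the scatter, and a step of similar size is expected here, a 1.1-fold higher number from compound 3 to compound 4 (0.03 log units; within the scatter), resting on that single measured precedent alone. Compound 4 is therefore estimated to give 6200 nM in this assay, with an expected range from 3000 nM to 12500 nM.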

Compound 4, half-maximal inhibitory concentration: > 50000 nM
Compound 4 ended at the assay's limit; the forecaster's own chance of this, stated with the estimate: 5%; at least 8.0-fold (0.90 log units) between middle value and limit.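

Compound 4 gives > 50000 nM in this assay, which is a limit of the assay and not a number: the limit of > 50000 nM in this assay, at which 1 of the 4 values shown sits.

On the core of compound 3, 4-hydroxyphenyl in place of 3-hydroxyphenyl gives an at least 8.5-fold higher number from compound 3 to compound 4 (0.93 log units; beyond the scatter), and the related exchange of 2-hydroxyphenyl for 3-hydroxyphenyl gives an at least 14-fold higher number from compound 2 to compound 4 (1.15 log units; beyond the scatter), so the small step seen on the core of compound 1 does not carry over to this core: the same change on two cores in this assay, a 1.1-fold higher number (0.06 log units; within the scatter) from compound 1 to compound 2 and an at least 8.5-fold higher number (0.93 log units; beyond the scatter) from compound 3 to compound 4, at least 7.5-fold (0.87 log units) apart, beyond the scatter of two such steps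

This shows that the step depends on the core for these two pairs only; it does not show how large the step on the core of compound 3 really is, as one end of it is a limit, and it does not show which difference between the two cores is responsible, nor whether the same holds on any further core in the series.

Still open, from the compounds shown here alone, is whether the same exchange would also reach the limit on other cores that carry a 2-hydroxyphenyl group. The compounds shown also leave open how a methoxy group or an amine in place of one of the hydroxyl groups would read in this assay.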